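A few compounds are considered here, and "the series" means these few. Any claim that something is new, unique, unknown or untested is made for them only; others in the source may bear on it.

Measured so far:
- compound 1, `CC[C@H](CCCc1cccnc1)NC(=O)/C=C/C=C(c1ccc(OC)cc1)c1ccc(OC)cc1`, gives 120 nM in an assay (Canis lupus familiaris) for binding affinity to platelet-activating factor receptor (Homo sapiens), read by radioligand binding; a higher number here means a weaker inhibitor, a lower number a stronger inhibitor
- compound 2, `COc1ccc(/C(=C/C=C/C(=O)N[C@H](C)CCCc2cccnc2)C2CCCCC2)cc1`, gives 20 nM in this assay

Of these two numbers, compound 1 has the higher one, so it is the weaker inhibitor of the pair, and the gap to compound 2 is beyond the usual scatter. The two compounds differ in more than one place, so that gap cannot be tied to any single change.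

The step to be followed here goes from compound 1 to compound 3, `COc1ccc(C(=C/C=C/C(=O)NCCCCc2cccnc2)c2ccc(OC)cc2)cc1`. The change is small: hydrogen in place of ethyl on a saturated chain carbon bound to an amide-type nitrogen and a saturated chain carbon. Compound 3 is not yet measured in this assay. Going by the values given here, no measured pair shows this change on its own, so there is no directly comparable step to lean on. Taking away a small group on the chain near the amide is expected to shift the number only modestly, with a step of about a 1.3-fold higher number from compound 1 to compound 3 (0.12 log units; within the scatter), toward a slightly weaker inhibitor. Compound 3 is therefore expected to give roughly 160 nM in this assay, within a range of 50 nM to 500 nM.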

Compound 3, half-maximal inhibitory concentration: 25 nM
For compound 3 the middle estimate is 6.4-fold (0.81 log units) above the measured one, outside the stated range (below it).
By their numbers in this assay, from the lowest: compounds 2 and 3 (each within the scatter of the next); then compound 1.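

In this assay, putting hydrogen in place of ethyl on the saturated chain carbon bound to an amide-type nitrogen and a saturated chain carbon gives a 4.8-fold lower number from compound 1 to compound 3 (0.68 log units; beyond the scatter). Going by these compounds alone, on this core, then, the ethyl group is not needed for a low number: the compound without it is the stronger inhibitor of this pair, which the earlier compounds, differing in more than one place, could not show. Nothing available explains this step.

Still open, going by these compounds, is how a longer chain such as propyl, or an amine or a hydroxyl group, would fare at this place. Also open, on these data alone, is whether hydrogen would give a step of similar size on another core, such as that of compound 2, which carries a methyl group here.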